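The source may hold more compounds than are shown below. What is called first, only, known or untested is meant among the compounds shown, and "the series" means these compounds.

Measured compounds in an assay on NIH3T3 cells with Urotensin-2 receptor (Homo sapiens) as the target; a lower number here means a smaller maximal response, a higher number a larger maximal response:
compound 1, `CN(C)CCC(NC(=O)c1ccc(Oc2ccccc2)cc1)c1ccc(Cl)cc1`, gives 89%
compound 2, `Cc1cccc(Cl)c1C(=O)NC(CCN(C)C)c1ccc(Cl)cc1`, gives 105%
compound 3, `CN(C)CCC(OC(=O)Nc1ccc(C(F)(F)F)cc1)c1ccc(Cl)cc1`, gives 94%

Among these three numbers compound 3 sits between the others. Compound 2 lies higher than compound 3 by a gap beyond the scatter, so compound 2 reaches a larger maximal response in this assay. Compound 1, on the other hand, lies within the scatter of compound 3, and no order between those two can be read from the data.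

The account now moves from compound 3 to compound 4, `CN(C)CCC(OC(=O)Nc1ccc(C(C)(C)C)cc1)c1ccc(Cl)cc1`, which has not yet been measured in this assay. The two structures differ in one place: tert-butyl in place of trifluoromethyl on an aromatic carbon. The rest of the molecule, the carbamate link, the basic side chain and the chlorinated aromatic ring, is kept. Going by the values given here, no step between two measured compounds of this set probes such an exchange, so the direction of the change rests on the shared framework alone.

Given that compound 3 gives 94%, compound 4 is expected to stay close to that level. The estimated step of a number 2 percentage points lower from compound 3 to compound 4 (within the scatter) is expected to be small, within the scatter, with no clear direction. For compound 4 the estimate in this assay is 92%, with a range from 75% to 106%.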

Compound 4, largest response reached (reported as efficacy), in percent of the reference or control that the assay uses: 105%
Beside the measured number, compound 4's estimate is 13 percentage points below it; the measured number falls inside the stated range.
By their numbers in this assay, from the lowest: compounds 1 and 3 (each within the scatter of the next); then compounds 2 and 4 (each within the scatter of the next).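

In this assay, going by these compounds alone, the exchange of trifluoromethyl for tert-butyl on an aromatic carbon, para to a large group, provides the first step between compounds that differ in one place, a number 11 percentage points higher from compound 3 to compound 4 (beyond the scatter). This shows that the maximal response is sensitive to the group at this position, even though the two groups have the same count of heavy atoms and neither brings a ring, a hydrogen-bond donor, a hydrogen-bond acceptor or a net charge. The step itself gives only a direction and a size for this one pair, and no measured property of the compounds bears on its origin.

On these data alone, it remains open whether the higher response belongs to tert-butyl in particular or would also appear with other groups at this position, such as a methyl, a chlorine, a methoxy or a nitrile. As far as these compounds go, it is equally open whether the same exchange would give a comparable step with an amide in place of the carbamate link, since this single pair tests it on the carbamate framework alone.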